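A few compounds are considered here, and "the series" means these few. Any claim that something is new, unique, unknown or untested is made for them only; others in the source may bear on it.

Measured in a functional assay on THP-1 cells (Homo sapiens) for inhibition, read by sulforhodamine B assay, with a stated time of 48 h, tested at 50 uM; on this read-out higher numbers stand for more inhibition of growth at the one concentration tested and lower numbers for less inhibition of growth:
- compound 1 `COc1cc(/C=C/C(=O)/C=C/c2cccc3ccccc23)ccc1OCc1cn(CCOc2cc(=O)oc3ccccc23)nn1`: 89%
- compound 2 `COc1cc(/C=C/C(=O)/C=C/c2cccc3ccccc23)ccc1OCc1cn(CCCOc2cc(=O)oc3ccccc23)nn1`: 71%
- compound 3 `COc1ccc(/C=C/C(=O)/C=C/c2ccc(OCc3cn(CCCCCOc4cc(=O)oc5ccccc45)nn3)c(OC)c2)cc1OC`: 47%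

Compound 3 stands lowest of the three, beyond the scatter from both compound 2 and compound 1. Compound 4 `COc1cc(/C=C/C(=O)/C=C/c2cccc3ccccc23)ccc1OCc1cn(CCCCCOc2cc(=O)oc3ccccc23)nn1` has naphthalen-1-yl in place of 3,4-dimethoxyphenyl on a double-bonded chain carbon bound to a double-bonded chain carbon. Among the measured compounds shown here, no measured pair shows this change alone. A modest rise in this assay is expected, resting on compound 2 at 71% and compound 1 at 89%, which both carry naphthalen-1-yl. The expected step is a number 8 percentage points higher from compound 3 to compound 4 (within the scatter), close to the scatter. Compound 4 is estimated at 55%, with an expected range of 38% to 72%.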

Compound 4, percent growth inhibition at one concentration: 44%
For compound 4 the middle estimate is 11 percentage points above the measured one, within the range that was stated.
By their numbers in this assay, from the lowest: compounds 4 and 3 (each within the scatter of the next); then compound 2; then compound 1.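

In this assay, naphthalen-1-yl in place of 3,4-dimethoxyphenyl on a double-bonded chain carbon bound to a double-bonded chain carbon gives a number 3 percentage points lower from compound 3 to compound 4 (within the scatter), so with this linking chain the exchange is not separated from the scatter. Naphthalen-1-yl alone therefore does not secure a high number: compound 4 gives 44% on the chain it carries, while compound 1 gives 89% on its shorter chain. Nothing available explains this result.

From the compounds shown here alone, whether 3,4-dimethoxyphenyl would match naphthalen-1-yl on the shorter chains of compound 1 and compound 2 stays open. Also open, going by these compounds, is how a phenyl ring bearing an amine or a carboxylic acid would read at this place.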